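The source may report more compounds than this note shows. Statements on the series, on what has been measured and on what is new or still open speak of the compounds shown alone.

Working notes on the series. In a functional assay on HepG2 cells (Homo sapiens) for inhibition, read by MTT assay, with a stated time of 72 h (on this read-out higher numbers stand for weaker inhibition and lower numbers for stronger inhibition), compound 1 `COc1ccccc1-n1c(-c2coc3cc(C)c(Cl)cc3c2=O)nc(-c2ccccc2)c1-c1ccccc1` gives 12500 nM while compound 2 `Cc1cc2occ(-c3nc(-c4ccccc4)c(-c4ccccc4)n3-c3ccc(Cl)c(Cl)c3)c(=O)c2cc1Cl` gives 12500 nM and compound 3 `Cc1cc2occ(-c3nc(-c4ccccc4)c(-c4ccccc4)n3-c3cccc([N+](=O)[O-])c3)c(=O)c2cc1Cl` gives 25000 nM so that compound 3 stands within the scatter of both others. The change to compound 4 `Cc1ccc(-n2c(-c3coc4cc(C)c(Cl)cc4c3=O)nc(-c3ccccc3)c2-c2ccccc2)cc1` is 4-methylphenyl in place of 3-nitrophenyl on an aromatic nitrogen. Three measured steps exchange the group on that same nitrogen, namely (no change at the digits printed from compound 1 to compound 2 (within the scatter)) and (a 2.0-fold higher number from compound 1 to compound 3 (0.30 log units; within the scatter)) and (a 2.0-fold higher number from compound 2 to compound 3 (0.30 log units; within the scatter)), and all stay within the scatter. Among the measured compounds shown here, no compound measured so far carries 4-methylphenyl, so this group itself is untested. No step beyond the scatter is therefore expected in this assay for this exchange. The expected step is a 1.7-fold lower number from compound 3 to compound 4 (0.22 log units; within the scatter) on this estimate. For compound 4 the estimated value is 15000 nM with an expected range from 6000 nM to 35000 nM in this read-out.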

Compound 4, half-maximal inhibitory concentration: 6250 nM
For compound 4 the middle estimate is 2.4-fold (0.38 log units) above the measured one, and the stated range covers the measured number.
By their numbers in this assay, from the lowest: compounds 4, 1, 2 and 3 (each within the scatter of the next, the first and the last beyond it).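

In this assay the aromatic nitrogen now gives its first step beyond the scatter, a 4.0-fold lower number from compound 3 to compound 4 (0.60 log units; beyond the scatter), whereas the three earlier exchanges on this nitrogen all stayed within it. The step holds only against 3-nitrophenyl: with a 2.0-fold lower number from compound 2 to compound 4 (0.30 log units; within the scatter) and a 2.0-fold lower number from compound 1 to compound 4 (0.30 log units; within the scatter), 4-methylphenyl stays within the scatter of both the 3,4-dichlorophenyl and the 2-methoxyphenyl groups, so compound 1 and compound 2 do not separate from compound 4. No evidence at hand bears on what lies behind the step.

Open, as far as these compounds go, is whether an amine or a carboxylic acid on the phenyl ring, or a longer alkyl chain in its place on this nitrogen, would move the number beyond the scatter of compound 4. Also open, from the compounds shown here alone, is whether the same exchange gives a step of this size on any other core.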